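Swapping a Carboxyphenyl for a Furan in a Cytotoxicity Series

The compounds below may be only part of what the source reports. "The series", "measured", "known", "first", "only" and "open" are said of these compounds alone.

Of the compounds shown here, two have so far been tested in an ADME assay on Vero cells (Chlorocebus sabaeus) for cytotoxicity, read by MTT assay, with a stated time of 72 h; on this read-out higher numbers stand for weaker inhibition and lower numbers for stronger inhibition. Compound 1 `O=C(c1ccncc1)N1N=C(c2cc3ccccc3o2)CC1c1ccccc1O` gives > 195000 nM, which is a limit of the assay rather than a number. Compound 2 `CCn1cc(C(=O)N2N=C(c3cc4ccccc4o3)CC2c2ccccc2C(=O)O)c(=O)c2ccc(C)nc21` gives > 196000 nM, again a limit of the assay and not a measured number. Compound 2 thus stands at the ceiling of what the assay reports, as the limit of > 196000 nM in this assay, at which 1 of the 2 values shown sits, and compound 1 sits at a comparable ceiling, as the limit of > 195000 nM in this assay, at which 1 of the 2 values shown sits. Among the measured compounds shown here, as both values are limits, no step between them can be sized. Compound 3 `CCn1cc(C(=O)N2N=C(c3cc4ccccc4o3)CC2c2ccco2)c(=O)c2ccc(C)nc21` has not yet been tested. It differs from compound 2 in one place: furan-2-yl in place of 2-carboxyphenyl on a saturated ring carbon. For the measured compounds named here, with no measured step available in this assay, the expectation is no change beyond the usual scatter. Compound 3 is therefore expected to give about 200000 nM, between 100000 nM and 400000 nM. The step that the limit leaves unreadable from compound 2 to compound 3 that this estimate means is expected to be essentially none.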

Compound 3, half-maximal inhibitory concentration: > 185000 nM
Compound 3 was reported as a limit; the forecaster's own chance of this, stated with the estimate: 80%; the middle value lies beyond the limit too.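

Compound 2 and compound 3 are both reported as limits in this assay, so the step from one to the other cannot be read. The compounds shown leave open whether furan-2-yl in place of 2-carboxyphenyl changes the read-out at all.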